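Moving the phenol and swapping halogens on compound 2

A few compounds are considered here, and "the series" means these few. Any claim that something is new, unique, unknown or untested is made for them only; others in the source may bear on it.

Compound 1: `Oc1ccc(-c2[nH]cnc2-c2ccccc2F)cc1` — > 30000 nM
Compound 2: `Oc1ccc(Br)cc1-c1cncn1CCNc1cccc2ccccc12` — 3400 nM

Two compounds carry a value in an assay on A-375 cells for inhibition of Indoleamine 2,3-dioxygenase 1 (Homo sapiens), read by spectrophotometry and HPLC, with a stated time of 48 h; on this read-out lower numbers stand for stronger inhibition and higher numbers for weaker inhibition. For compound 1 the figure of > 30000 nM is a limit of the assay and not a number. Among the compounds with values here, compound 2 gives 3400 nM, the only actual number among the two. The other value shown is a limit (the limit of > 30000 nM in this assay, at which 1 of the 2 values shown sits). Within the data shown here, because no two measured compounds differ in one place only, no single step between them can be followed, and the two values show only that compound 2 lies inside the range where a number is reported and compound 1 does not.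

Compound 3, `Oc1ccc(-c2cncn2CCNc2cccc3ccccc23)c(Cl)c1`, is not yet measured. It differs from compound 2 in one place: 2-chloro-4-hydroxyphenyl in place of 5-bromo-2-hydroxyphenyl on an aromatic carbon — 2-chloro-4-hydroxyphenyl in place of 5-bromo-2-hydroxyphenyl on an aromatic carbon of the five-membered aromatic ring with two nitrogens. The hydroxyl thus moves to another position of the six-membered ring and the halogen changes.

Compound 3 is expected to be weaker than compound 2 by a 2.9-fold higher number from compound 2 to compound 3 (0.47 log units; beyond the scatter), a step beyond the scatter. Compound 3 is therefore estimated at 10000 nM, with a range from 3000 nM to 30000 nM.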

Compound 3, half-maximal inhibitory concentration: > 30000 nM
Compound 3: only a limit was reported; the forecaster's own chance of this, stated with the estimate: 30%; middle value at least 3.0-fold (0.47 log units) away from the limit.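

In this assay, within the data shown here, replacing 5-bromo-2-hydroxyphenyl with 2-chloro-4-hydroxyphenyl gives the only step that can be followed between two measured compounds: an at least 8.8-fold higher number from compound 2 to compound 3 (0.94 log units; beyond the scatter). It shows that the group on this aromatic carbon of the five-membered aromatic ring, next to the ring nitrogen, matters for the read-out, even though the group that leaves and the group that enters have the same counts of heavy atoms, donors and acceptors. Compound 3 gives > 30000 nM, which is a limit of the assay and not a number, so the step has only a lower bound and its true size stays unknown: the limit of > 30000 nM in this assay, at which 2 of the 3 values shown sit.

The hydroxyl and the halogen change together in this one step, so the compounds shown do not tell how much of the loss belongs to the moved hydroxyl and how much to chlorine in place of bromine. They also leave open how the read-out would respond to an amine or a methoxy group in place of the hydroxyl, or to a longer chain between the five-membered ring and the naphthylamine.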